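This account rests on a few compounds, and the source may have more. Where it says the series, first, only, none or still open, it means among the compounds named here.

In a functional assay on SK-MEL-28 cells (Homo sapiens) for inhibition, read by colorimetric assay and MTT assay, with a stated time of 72 h (on this read-out lower numbers stand for stronger inhibition and higher numbers for weaker inhibition), three compounds have been measured so far. Compound 1 `C=CCCCCCOc1ncc(-c2ccccc2OCCCCC=C)n1C` gives 79000 nM. Compound 2 `Cn1c(-c2ccccc2O)cnc1S(=O)(=O)c1ccccc1` gives > 100000 nM, which is a limit of the assay and not a number. Compound 3 `C=CCCCCOc1ccccc1-c1cnc(S(=O)(=O)c2ccccc2)n1C` gives 38000 nM, the lowest of the values in hand.

Compound 4 `C=CCCOc1ccccc1-c1cnc(S(=O)(=O)c2ccccc2)n1C` differs from compound 3 in one place: vinyl in place of but-3-en-1-yl on a saturated chain carbon, two bonds along the chain from an oxygen on an aromatic ring. Cut one bond further out, hex-5-en-1-yl becomes but-3-en-1-yl, so the chain gets shorter.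

The measured step closest to this change is an at least 2.6-fold lower number from compound 2 to compound 3 (0.42 log units; beyond the scatter), where hex-5-en-1-yl replaced hydrogen on that same oxygen. The other step, a 2.1-fold lower number from compound 1 to compound 3 (0.32 log units; beyond the scatter), concerns a different place, phenylsulfonyl in place of (hept-6-en-1-yl)oxy on an aromatic carbon, so it bears on this change only weakly.

Compound 4 still carries a chain on the oxygen, so it is expected to give back only part of the gain seen at compound 3, with its 38000 nM. The expected change is small and toward a higher number, and it may stay within the scatter: a 1.6-fold higher number from compound 3 to compound 4 (0.20 log units; within the scatter). For compound 4 the estimated value is 60000 nM, with an expected range from 30000 nM to 100000 nM.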

Compound 4, half-maximal inhibitory concentration: 60000 nM
Estimate against measurement, compound 4: no gap at the digits printed; low and high end bracket the measured number.
By their numbers in this assay, from the lowest: compounds 3, 4 and 1 (each within the scatter of the next, the first and the last beyond it). At a limit, above all of these: compound 2.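

Cutting the chain on the oxygen from hex-5-en-1-yl to but-3-en-1-yl gives a 1.6-fold higher number from compound 3 to compound 4 (0.20 log units; within the scatter) in this assay, so this read-out does not separate the two chain lengths at this position. Set against hydrogen on that same oxygen, the shorter chain gives an at least 1.6-fold lower number from compound 2 to compound 4 (0.22 log units; that floor lies within the scatter), whereas the floor for the longer chain, an at least 2.6-fold lower number from compound 2 to compound 3 (0.42 log units; beyond the scatter), clears the scatter, so only hex-5-en-1-yl has so far shown a gain over hydrogen that can be read. From the compounds shown here alone, compound 2 gives a limit of the assay and not a number, so the true size of both steps from it stays unknown: the limit of > 100000 nM in this assay, at which 1 of the 4 values shown sits.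

Every chain shown on this oxygen ends in a double bond, so it remains open whether a saturated hexyl chain, or a chain ending in an amine or a carboxylic acid, would read any differently. Going by these compounds, it is also open whether a chain longer than hex-5-en-1-yl on this oxygen would separate from compound 3 by more than the scatter.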